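Cyclopentyl to Ethyl on the Ketone Side Chain

The source may report more compounds than this note shows. Statements on the series, on what has been measured and on what is new or still open speak of the compounds shown alone.

Of the compounds shown here, three that share one core have been measured in an assay on HEK293 cells for positive allosteric modulation of metabotropic glutamate receptor 2 (Rattus norvegicus), read by thallium flux, with a stated time of 2.5 min; a lower number here means a smaller maximal response, a higher number a larger maximal response. Compound 1 `CCC(=O)c1ccc(OCCCCOc2ccc(F)c(C(=O)O)c2)c(C)c1O` gives 66.6% in this assay. Compound 2 `Cc1c(OCCCCOc2ccc(F)c(C(=O)O)c2)ccc(C(=O)CC2CCCC2)c1O` gives 81%, and compound 3 `COc1ccc(C(=O)O)cc1OCCCCOc1ccc(C(=O)CC2CCCC2)c(O)c1C` gives 91.8%. Among these three numbers compound 2 stands second highest: the nearest step is a number 10.8 percentage points higher from compound 2 to compound 3 (beyond the scatter), modest but beyond the scatter, and the furthest is a number 14.4 percentage points higher from compound 1 to compound 2 (beyond the scatter), also modest and beyond the scatter.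

Compound 4 `CCCC(=O)c1ccc(OCCCCOc2ccc(F)c(C(=O)O)c2)c(C)c1O` has not yet been measured in this assay. It differs from compound 2 in one place: ethyl in place of cyclopentyl on a saturated chain carbon bound to a carbonyl carbon. Among the measured compounds shown here, only one measured step concerns this position, a number 14.4 percentage points higher from compound 1 to compound 2 (beyond the scatter), in which the larger group went with the larger maximal response. The change to compound 4 partly undoes that step, since the group that enters is smaller than cyclopentyl yet larger than methyl. A fall in this assay is therefore expected, smaller than the rise seen between compound 1 and compound 2, so that compound 4 should land between them. Compound 4 is accordingly expected at an estimated 72%, with a range from 60% to 84%. That estimate means a step of a number 9 percentage points lower from compound 2 to compound 4 (within the scatter), a modest expected decrease.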

Compound 4, largest response reached (reported as percent of maximum), in percent of the reference or control that the assay uses: 87.5%
Compound 4: middle estimate off by 15.5 percentage points, on the low side; measured number outside the range, above it.
By their numbers in this assay, from the lowest: compound 1; then compounds 2, 4 and 3 (each within the scatter of the next, the first and the last beyond it).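

In this assay, putting ethyl in place of cyclopentyl on this saturated chain carbon bound to a carbonyl carbon gives a number 6.5 percentage points higher from compound 2 to compound 4 (within the scatter), so compound 2 and compound 4 cannot be told apart and the cyclopentyl ring is not required for a response of this size. The contrast with compound 1 is carried instead by a much smaller change, methyl in place of hydrogen on a saturated chain carbon, two bonds along the chain from a carbonyl carbon, which gives a number 20.9 percentage points higher from compound 1 to compound 4 (beyond the scatter), and the earlier step from compound 1 to compound 2 can no longer be read as a simple gain from the ring. Nothing among the data shown accounts for this behaviour at the position.

The compounds shown leave open how the response would run with a longer open chain such as butyl, with a branched group such as isopropyl, or with an amine or a hydroxyl on the chain. They also leave open whether propyl on the ketone would hold up alongside the 5-carboxy-2-methoxyphenyl group of compound 3.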